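Bromo to benzyloxy on a two-ring shared core

A few compounds are considered here, and "the series" means these few. Any claim that something is new, unique, unknown or untested is made for them only; others in the source may bear on it.

Measured so far:
compound 1, `Cc1ccc(S(=O)(=O)n2cc(-c3cc(C(F)(F)F)c(C#N)c(-c4cn(S(=O)(=O)c5ccc(C)cc5)c5ccc(Br)cc45)n3)c3cc(Br)ccc32)cc1`, 9.6%
compound 2, `Cc1ccc(S(=O)(=O)n2cc(-c3cc(C(F)(F)F)ccn3)c3cc(Br)ccc32)cc1`, 20.6%

Of the two measured compounds, compound 2 stands highest in a functional assay on A549 cells (Homo sapiens) for inhibition, tested at 10 uM; on this read-out higher numbers stand for a stronger effect at the one concentration tested and lower numbers for a weaker effect: in this assay compound 2 gives 20.6%, and the nearest number is that of compound 1, which lies lower by a gap beyond the scatter. Compound 3, `Cc1ccc(S(=O)(=O)n2cc(-c3cc(C(F)(F)F)ccn3)c3cc(OCc4ccccc4)ccc32)cc1`, has not yet been measured. It differs from compound 2 in one place: benzyloxy in place of bromo on an aromatic carbon. Among the compounds with values here, no step between measured compounds tells how such a change shifts the read-out, so the expectation rests on compound 2 alone. The step from compound 2 to compound 3 is expected to be small, a number 1.4 percentage points higher from compound 2 to compound 3 (within the scatter), with no direction clearly favoured beyond the usual scatter. Compound 3 is therefore estimated at 22% in this assay, within a range from 5% to 45%.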

Compound 3, a percentage reported as inhibition, at one concentration (the size of the read-out at that concentration, not a potency): 9.9%
Compound 3: middle estimate off by 12.1 percentage points, on the high side; measured number inside the range.
By their numbers in this assay, from the lowest: compounds 1 and 3 (each within the scatter of the next); then compound 2.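

Within the data shown here, the new pair gives the first reading of this position: in this assay, benzyloxy in place of bromo on the shared core gives a number 10.7 percentage points lower from compound 2 to compound 3 (beyond the scatter), a modest step that lies beyond the scatter. The position is therefore not indifferent to this change, at least for this one exchange of a single bromine atom for a group that brings an oxygen and a further aromatic ring. Nothing measured here bears on why the read-out moves this way.

Going by these compounds, with only this one replacement, it stays open whether the oxygen link or the added ring carries the step. On these data alone, whether a methoxy group, an amine or a carboxylic acid at this carbon would stay near compound 2 or fall as compound 3 does also remains open.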